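A few compounds are considered here, and "the series" means these few. Any claim that something is new, unique, unknown or untested is made for them only; others in the source may bear on it.

In a functional assay on Caco-2 cells (Homo sapiens) for cytotoxicity, read by cell counting, with a stated time of 48 h (on this read-out higher numbers stand for weaker inhibition and lower numbers for stronger inhibition), three compounds have been measured so far:

compound 1 `Clc1ccc(-n2cc(COc3cccc4cnc(Nc5cccc(Cl)c5)nc34)nn2)cc1` gives 24000 nM
compound 2 `COc1ccccc1-n1cc(COc2cccc3cnc(Nc4cccc(Cl)c4)nc23)nn1` gives > 25000 nM which is a limit of the assay
compound 3 `Clc1cccc(Nc2ncc3cccc(OCc4cn(-c5ccc(Br)cc5)nn4)c3n2)c1` gives 11000 nM

Compound 3 holds the lower of the two actual numbers, and its nearest neighbour is compound 1, with a 2.2-fold lower number from compound 1 to compound 3 (0.34 log units; beyond the scatter) for bromo in place of chloro on an aromatic carbon. Compound 4 `COc1cccc(-n2cc(COc3cccc4cnc(Nc5cccc(Cl)c5)nc34)nn2)c1` has not yet been measured. It departs from compound 3 by a single change 3-methoxyphenyl in place of 4-bromophenyl on an aromatic nitrogen in which 3-methoxyphenyl takes the place of 4-bromophenyl on an aromatic nitrogen.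

The closest guide is an at least 2.2-fold lower number from compound 2 to compound 3 (0.35 log units; beyond the scatter) for 4-bromophenyl in place of 2-methoxyphenyl on an aromatic nitrogen. Read in reverse, it points to a higher number when a methoxyphenyl group replaces 4-bromophenyl, although compound 2 carries 2-methoxyphenyl and compound 4 carries 3-methoxyphenyl. The other methoxyphenyl step, an at least 1.0-fold higher number from compound 1 to compound 2 (0.01 log units; that floor lies within the scatter) for 2-methoxyphenyl in place of 4-chlorophenyl, offers only a floor. A modest rise is therefore expected in this assay and the estimated step is a 1.8-fold higher number from compound 3 to compound 4 (0.26 log units; within the scatter) for this change. Compound 4 might also be reported only at the limit of > 25000 nM in this assay, at which 1 of the 3 values shown sits, rather than as a number. For compound 4 the estimated value is 20000 nM with an expected range from 11000 nM to 32000 nM.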

Compound 4, half-maximal inhibitory concentration: 20000 nM
Estimate against measurement, compound 4: no gap at the digits printed; measured number inside the range.
By their numbers in this assay, from the lowest: compounds 3, 4 and 1 (each within the scatter of the next, the first and the last beyond it). At a limit, above all of these: compound 2.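

On the aromatic nitrogen, compound 4 gives the first methoxyphenyl result that is an actual number, so this exchange can be read in full, and in this assay it stays within the scatter (a 1.8-fold higher number from compound 3 to compound 4 (0.26 log units; within the scatter)). The comparison with 4-chlorophenyl also stays within the scatter (a 1.2-fold lower number from compound 1 to compound 4 (0.08 log units; within the scatter)), so compound 4 cannot be separated from either of these two compounds, although the step between them lies beyond the scatter (a 2.2-fold lower number from compound 1 to compound 3 (0.34 log units; beyond the scatter)). Moving the methoxy group from 2-methoxyphenyl to 3-methoxyphenyl yields only a floor within the scatter (an at least 1.2-fold lower number from compound 2 to compound 4 (0.09 log units; that floor lies within the scatter)), and the value of compound 2 is a limit: (the limit of > 25000 nM in this assay, at which 1 of the 4 values shown sits).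

Every compound shown carries a substituted phenyl on this nitrogen, so it remains open what unsubstituted phenyl, 4-methoxyphenyl, or a phenyl bearing an amine or a carboxylic acid would give in this assay. On these data alone, it also remains open whether the bromo-for-chloro step seen with 4-bromophenyl would recur with other groups at this position, as that step rests on a single pair of compounds.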